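Working notes: compound 3 to compound 4

A few compounds are considered here, and "the series" means these few. Any claim that something is new, unique, unknown or untested is made for them only; others in the source may bear on it.

In an in vitro functional assay on HEK285-7 cells for antagonist activity at prostaglandin D2 receptor 2 (Homo sapiens), read by BRET and beta-arrestin recruitment (on this read-out lower numbers stand for smaller maximal responses and higher numbers for larger maximal responses), compound 3 `O=C(O)Cc1sc(C(c2ccc(F)cc2)c2ccc(F)cc2)nc1-c1cn[nH]c1` gives 80%. Compound 1 `O=C(O)Cc1sc(C(c2ccc(F)cc2)c2ccc(F)cc2)nc1-c1ccnc(N2CCCC2)c1` gives 80% in this assay, and compound 2 `O=C(O)Cc1sc(C(c2ccc(F)cc2)c2ccc(F)cc2)nc1-c1cc(F)cc(F)c1` gives 80%. The steps of no change at the digits printed from compound 1 to compound 3 (within the scatter) and no change at the digits printed from compound 2 to compound 3 (within the scatter) are flat, so compound 3 stands level with compounds 1 and 2 on the maximal response.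

Compound 4 `CN(C)c1cc(-c2nc(C(c3ccc(F)cc3)c3ccc(F)cc3)sc2CC(=O)O)ccn1` differs from compound 3 as follows: 2-(dimethylamino)pyridin-4-yl in place of 1H-pyrazol-4-yl on an aromatic carbon. Among the measured compounds shown here, two measured steps bear on this. The step of no change at the digits printed from compound 1 to compound 3 (within the scatter) exchanged a 2-(pyrrolidin-1-yl)pyridin-4-yl for the same 1H-pyrazol-4-yl that now leaves, and it stayed within the scatter. The step of no change at the digits printed from compound 1 to compound 2 (within the scatter) exchanged that group for 3,5-difluorophenyl, again within the scatter. For the measured compounds named here, every change at this position so far has left the maximal response unmoved, and the entering 2-(dimethylamino)pyridin-4-yl is a near relative of the group in compound 1. A step of about no change at the digits printed from compound 3 to compound 4 (within the scatter) is therefore expected, none beyond the scatter. For compound 4 the estimate in this assay is 80%, with a range from 70% to 90%.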

Compound 4, largest response reached (reported as efficacy), in percent of the reference or control that the assay uses: 80%
The estimate for compound 4 equals the measured number at the digits printed, and the stated range covers the measured number.
By their numbers in this assay, from the lowest: compounds 1, 2, 3 and 4 (each within the scatter of the next).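

Among the compounds shown here, the step of no change at the digits printed from compound 1 to compound 4 (within the scatter) in this assay is the first change confined to the amine on the pyridine, and an open-chain dimethylamino group serves as well as the ring-closed pyrrolidin-1-yl there. Moving from a five-membered aromatic ring with a hydrogen-bond donor to the 2-(dimethylamino)pyridin-4-yl group, which has none, gives no change at the digits printed from compound 3 to compound 4 (within the scatter) as the step, and replacing 3,5-difluorophenyl with the same group gives no change at the digits printed from compound 2 to compound 4 (within the scatter) as the step, so the position has so far tolerated all four groups. No measurement at hand explains this flat read-out.

On these data alone, whether a carboxylic acid or a piperidin-4-yl group at this position would move the maximal response remains open. All four compounds also share the carboxymethyl group and the large group, so nothing here tests changes at those places.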